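Removing the methyl and reshaping the ring of compound 2

The source may report more compounds than this note shows. Statements on the series, on what has been measured and on what is new or still open speak of the compounds shown alone.

Compound 1 `CCS[C@@H]1[C@H](SCC)[C@@H](Cn2cc(-c3ccccc3)nn2)O[C@H]1n1ccc(=O)[nH]c1=O`: 8380 nM
Compound 2 `CCS[C@@H]1[C@H](SCC)[C@@H](Cn2cc(-c3ccccc3)nn2)O[C@H]1n1cc(C)c(=O)[nH]c1=O`: 65000 nM
Compound 3 `CCOC(=O)c1cn(C[C@H]2O[C@@H](n3cc(C)c(=O)[nH]c3=O)[C@H](SCC)[C@@H]2SCC)nn1`: >= 100000 nM (a limit of the assay)

In a functional assay on HepG2 cells (Homo sapiens) for cytotoxicity, read by MTT assay, with a stated time of 72 h (a higher number here means that more compound is needed for the effect, a lower number that less compound is needed), compound 2 gives the highest of the two numbers shown; the next is compound 1, with a 7.8-fold higher number from compound 1 to compound 2 (0.89 log units; beyond the scatter). Compound 3 reports only a limit, (the limit of >= 100000 nM in this assay, at which 1 of the 3 values shown sits), and the step of an at least 1.5-fold higher number from compound 2 to compound 3 (0.18 log units; that floor lies within the scatter) is therefore only a floor. Compound 4 `CCS[C@@H]1[C@H](SCC)[C@@H](Cn2cc(-c3ccccc3)nn2)O[C@H]1n1ccc(N)nc1=O` differs from compound 2 by a group of 8 heavy atoms (4 carbon, 3 nitrogen, 1 oxygen; one six-membered aromatic ring with 2 hetero atoms) in place of a group of 9 heavy atoms (5 carbon, 2 nitrogen, 2 oxygen; one six-membered aromatic ring with 2 hetero atoms), on a saturated ring carbon. For the measured compounds named here, the one measured step that bears on this change is the methyl step, a 7.8-fold higher number from compound 1 to compound 2 (0.89 log units; beyond the scatter), which compound 4 undoes while also altering the ring itself. Going by the values given here, the reshaped ring has no measured precedent here, so the expected step is a 3.3-fold lower number from compound 2 to compound 4 (0.51 log units; beyond the scatter), with wide uncertainty. Compound 4 is estimated at 20000 nM, within 4000 nM to 100000 nM.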

Compound 4, half-maximal effective concentration: 57100 nM
Estimate against measurement, compound 4: 2.9-fold (0.46 log units) below, within the range that was stated.
By their numbers in this assay, from the lowest: compound 1; then compounds 4 and 2 (each within the scatter of the next). At a limit, above all of these: compound 3.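

In this assay, the exchange of ring groups on this saturated ring carbon, a 1.1-fold lower number from compound 2 to compound 4 (0.06 log units; within the scatter), leaves compound 2 and compound 4 indistinguishable. Compound 4 lacks the methyl, as compound 1 does, yet the change of ring group alone gives a 6.8-fold higher number from compound 1 to compound 4 (0.83 log units; beyond the scatter), so the absence of that methyl does not by itself bring the lower number of compound 1. Nothing measured here accounts for either step. On these data alone, what a fluorine or a longer chain in place of that methyl would do stays open, as does the effect of a methyl added to the ring group of compound 4.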